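Tert-butoxy for Methyl on the Carbonyl: Cytotoxicity Outlook

This account rests on a few compounds, and the source may have more. Where it says the series, first, only, none or still open, it means among the compounds named here.

Compound 1 `CN(C(=O)OC(C)(C)C)C(=O)c1ccc(CN2C(=O)c3ccccc3S2(=O)=O)cc1`, in an ADME assay on RAW264.7 cells (Mus musculus) for cytotoxicity, read by WST assay; a lower number here means that less compound is tolerated, a higher number that more compound is tolerated: > 100000 nM, a limit of the assay.
Compound 2 `CC(=O)N(Cc1ccco1)C(=O)c1ccc(CN2C(=O)c3ccccc3S2(=O)=O)cc1`, in this assay : > 100000 nM, also a limit.

Compound 2 thus stands at the assay limit, where (the limit of > 100000 nM in this assay, at which 2 of the 2 values shown sit). Among the compounds with values here, the one measured step, from compound 1 to compound 2, reads a step that the two limits leave unreadable from compound 1 to compound 2. Compound 3 `CC(C)(C)OC(=O)N(Cc1ccco1)C(=O)c1ccc(CN2C(=O)c3ccccc3S2(=O)=O)cc1` differs from compound 2 by tert-butoxy in place of methyl on a carbonyl carbon. Compound 1 carries the same tert-butoxycarbonyl group and sits at the limit, so no step beyond the scatter is expected in this assay. The expected step is a number no higher from compound 2 to compound 3 (the limit leaves the size open). Compound 3 is therefore estimated at 100000 nM, between 50000 nM and 200000 nM.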

Compound 3, concentration lethal to 50% of the cells: > 100000 nM
Compound 3 was reported as a limit; the forecaster's own chance of this, stated with the estimate: 85%; the middle value sits exactly at the limit.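

In this assay compound 3 gives > 100000 nM, a limit of the assay. Its steps to compound 1 and compound 2 cannot be read. The compounds shown leave open where the lethal concentration of each one actually lies.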